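The compounds below may be only part of what the source reports. "The series", "measured", "known", "first", "only" and "open" are said of these compounds alone.

Measured compounds:
Compound 1, `CN(C)CCn1cnnc1-c1cc(Oc2ccc(NC(=O)N/N=C/c3ccc(O)c(O)c3)cc2F)ccn1`: in a functional assay on NCI-H460 cells (Homo sapiens) for cytotoxicity, read by MTT assay, with a stated time of 72 h (on this read-out higher numbers stand for weaker inhibition and lower numbers for stronger inhibition), compound 1 gives 1930 nM.
Compound 2, `CN(C)CCn1cnnc1-c1cc(Oc2ccc(NC(=O)N/N=C/c3cc(C(C)(C)C)cc(C(C)(C)C)c3O)cc2F)ccn1`: in this assay compound 2 gives 590 nM.
Compound 3, `CN(C)CCn1cnnc1-c1cc(Oc2ccc(NC(=O)N/N=C/c3ccc(O)cc3)cc2F)ccn1`: in this assay compound 3 gives 1780 nM.

Compound 3 stands second highest of the three numbers. Its nearest neighbour is compound 1, and the two values lie within the scatter of each other, so neither can be called more potent. Compound 2 is the odd one out, with a lower number than compound 3, a gap that lies beyond the scatter.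

The unmeasured compound 4, `CN(C)CCn1cnnc1-c1cc(Oc2ccc(NC(=O)N/N=C/c3ccc(F)cc3)cc2F)ccn1`, differs from compound 3 in one place: fluoro in place of hydroxy on an aromatic carbon. Within the data shown here, the one measured step that bears on this change is the removal of a hydroxy from an aromatic carbon, a 1.1-fold lower number from compound 1 to compound 3 (0.04 log units; within the scatter), which left the number essentially unchanged. Both that step and the present one take away a hydroxy with its hydrogen-bond donor and acceptor, so by analogy the number is expected to shift little. Among the measured compounds shown here, no measured compound carries a fluoro on this ring, so the expectation is loose.

Compound 4 is therefore expected to give about 1500 nM in this assay, with a range of 600 nM to 3800 nM, which corresponds to an expected step of a 1.2-fold lower number from compound 3 to compound 4 (0.07 log units; within the scatter).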

Compound 4, half-maximal inhibitory concentration: 1980 nM
Compound 4: the middle estimate sits 1.3-fold (0.12 log units) below what was measured, and the stated range covers the measured number.
By their numbers in this assay, from the lowest: compound 2; then compounds 3, 1 and 4 (each within the scatter of the next).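

Compound 3 kept one hydroxy on this ring, so the earlier step left open whether the last one mattered. Exchanging it for fluoro, the change from 4-hydroxyphenyl to 4-fluorophenyl, gives a 1.1-fold higher number from compound 3 to compound 4 (0.05 log units; within the scatter) in this assay, and a comparison with the two-hydroxy ring gives a 1.0-fold higher number from compound 1 to compound 4 (0.01 log units; within the scatter); across compounds 1, 3 and 4, then, the ring can carry two hydroxy groups, one, or none at all with a fluoro in their place, and the number stays within the scatter. This also means that losing every hydrogen-bond donor and acceptor counted on these ring substituents leaves no readable mark on the cytotoxicity read-out, though nothing available explains why the number holds steady.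

Still open, from the compounds shown here alone, is whether an amine, a carboxylic acid or a methoxy group at this same ring position would also leave the number in place, or would finally move it. Also open is which feature of the ring in compound 2, at 590 nM, goes with its lower number, as a ring bearing tert-butyl groups without the hydroxy does not appear among these compounds.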